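Methylating the Ring Nitrogen of Compound 2

The compounds below may be only part of what the source reports. "The series", "measured", "known", "first", "only" and "open" are said of these compounds alone.

Of the compounds shown here, three share one core and have been measured. Compound 1 `CCCOC(=O)C1=C(C)NC(=O)NC1c1ccco1` gives 3% in an assay on membranes from HeLa cells for displacement of a labelled ligand from adenosine receptor A3 (Homo sapiens), read by scintillation counting, with a stated time of 180 min, tested at 1 uM; a lower number here means less inhibition, a higher number more inhibition at the concentration tested (going by the name of the read-out). Compound 2 `CCCOC(=O)C1=C(C)NC(=O)NC1c1cccs1` gives 32% in this assay, and compound 3 `CC1=C(C(=O)OCc2ccccc2)C(c2cccs2)NC(=O)N1` gives 8% in this assay. Compound 2 therefore stands highest of the three, and both other numbers lie beyond the scatter below it.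

Two steps between measured compounds are known. One swaps the aromatic ring on the saturated ring carbon: a number 29 percentage points higher from compound 1 to compound 2 (beyond the scatter). The other changes the ester chain: a number 24 percentage points lower from compound 2 to compound 3 (beyond the scatter).

Compound 4 `CCCOC(=O)C1=C(C)N(C)C(=O)NC1c1cccs1` differs from compound 2 by methyl in place of hydrogen on an amide-type nitrogen in a ring. For the measured compounds named here, neither measured step touches this ring nitrogen, so no measured step bears directly on the change, and the numbers so far give no lead on its direction. The reasonable expectation in this assay is a step not beyond the scatter, with a wide range on either side to allow for a change of modest size such as the two measured steps showed. Compound 4 is thus estimated at 25%, with a range from 5% to 45%. That estimate means the step expected is a number 7 percentage points lower from compound 2 to compound 4 (within the scatter).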

Compound 4, a percentage reported as inhibition, at one concentration (the size of the read-out at that concentration, not a potency): 4%
Beside the measured number, compound 4's estimate is 21 percentage points above it; measured number outside the range, below it.
By their numbers in this assay, from the lowest: compounds 1, 4 and 3 (each within the scatter of the next); then compound 2.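

For the compounds shown here, this is the first change at the ring nitrogen: in this assay, methyl in place of hydrogen gives a number 28 percentage points lower from compound 2 to compound 4 (beyond the scatter) and so lies beyond the usual scatter of the assay. The earlier steps shown here changed the aromatic ring on the saturated ring carbon or the ester chain, whereas this one shows that the core itself responds to a single added heavy atom, on an amide-type nitrogen next to the ring atom that bears a methyl group, and that the amide hydrogen of compound 2 cannot be replaced by methyl without a loss of inhibition at the concentration tested. This rests on one pair of compounds, and nothing measured here explains the drop.

The compounds shown leave open whether an ethyl group or a longer chain on this nitrogen would lower the number in the same way, and whether a methyl group on the other ring nitrogen would do the same. They also leave open whether the same methyl group would have a step of similar size on a compound with a different ester chain or with furan-2-yl in place of thiophen-2-yl.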